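Replacing an Aromatic Amide Group with an Aminoalkyl Chain

This account rests on a few compounds, and the source may have more. Where it says the series, first, only, none or still open, it means among the compounds named here.

In a functional assay on 143B cells (Homo sapiens) for inhibition, read by MTT assay, with a stated time of 72 h (on this read-out higher numbers stand for weaker inhibition and lower numbers for stronger inhibition), compound 1 `O=C(CCC(=O)OCCCCCCSc1ccc([N+](=O)[O-])c2nonc12)Nc1ccccc1F` gives 3030 nM and compound 2 `Cc1ccc(NC(=O)CCC(=O)OCCCCCCSc2ccc([N+](=O)[O-])c3nonc23)cc1` gives 3250 nM, so compound 2 stands level with compound 1. Among the measured compounds shown here, the only measured step, a 1.1-fold higher number from compound 1 to compound 2 (0.03 log units; within the scatter), lies within the scatter, but it exchanges one substituted phenyl group for another and is a weak guide here. Compound 3 `CCN(CC)CCCNC(=O)CCC(=O)OCCCCCCSc1ccc([N+](=O)[O-])c2nonc12` carries 3-(diethylamino)propyl in place of 4-methylphenyl on an amide-type nitrogen. For the measured compounds named here, with no measured step of this kind, a modest change of uncertain direction is expected, estimated as a 1.3-fold lower number from compound 2 to compound 3 (0.11 log units; within the scatter). Compound 3 is expected at 2500 nM, with an estimated range of 700 nM to 9000 nM.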

Compound 3, half-maximal inhibitory concentration: 3440 nM
Estimate against measurement, compound 3: 1.4-fold (0.14 log units) below, and the stated range covers the measured number.
By their numbers in this assay, from the lowest: compounds 1, 2 and 3 (each within the scatter of the next).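

Putting the open 3-(diethylamino)propyl chain on the amide-type nitrogen in place of 4-methylphenyl removes the aromatic ring and adds a nitrogen, yet the result in this assay is close (a 1.1-fold higher number from compound 2 to compound 3 (0.02 log units; within the scatter)). The same holds against 2-fluorophenyl (a 1.1-fold higher number from compound 1 to compound 3 (0.06 log units; within the scatter)), so among these three compounds an aromatic ring at this position is not needed to keep the number at this level. Nothing available explains why the number stays level.

From the compounds shown here alone, it remains open whether the diethylamino group matters, or only the chain that carries it. A plain alkyl chain without an amine, a longer chain, or a carboxylic acid in its place could help separate the two.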